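Replacing One Methoxyphenyl Arm with a Bromofluorophenyl Arm

The compounds below may be only part of what the source reports. "The series", "measured", "known", "first", "only" and "open" are said of these compounds alone.

Measured so far:
Compound 1 `COc1ccccc1/C=c1/[nH]c(=O)/c(=C\c2ccccc2OC)[nH]c1=O` gives "not active" (no number reported) in a functional assay on U-937 cells (Homo sapiens) for cytotoxicity, read by CCK-8 assay, with a stated time of 72 h; on this read-out lower numbers stand for stronger inhibition and higher numbers for weaker inhibition.
Compound 2 `C=CCn1c(=O)/c(=C\c2ccccc2OC)[nH]c(=O)/c1=C\c1ccccc1OC` gives 5100 nM in this assay.

In this assay, for the measured compounds named here, compound 2 is the only compound with a number attached; compound 1 is recorded as "not active" (no number reported) with no figure, so it cannot be placed above or below compound 2. Compound 2 therefore stands alone as the single measured potency in this set.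

Compound 3 `C=CCn1c(=O)/c(=C\c2cc(Br)ccc2F)[nH]c(=O)/c1=C\c1ccccc1OC` keeps the core of compound 2 and differs from it in one place: 5-bromo-2-fluorophenyl in place of 2-methoxyphenyl on a double-bonded chain carbon bound to an aromatic carbon. Going by the values given here, no step between two measured compounds is available here, so nothing in the data shows how an exchange of this kind moves the read-out, and any expectation rests on the single value of compound 2 alone.

The step from compound 2 to compound 3 is expected to be a 1.1-fold lower number from compound 2 to compound 3 (0.05 log units; within the scatter), that is, no change beyond the scatter in either direction. Compound 3 is accordingly expected to give about 4500 nM in this assay, with a range from 1200 nM to 17000 nM.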

Compound 3, half-maximal inhibitory concentration: 4700 nM
Estimate against measurement, compound 3: 1.0-fold (0.02 log units) below, and the stated range covers the measured number.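

In this assay, for the compounds shown here, putting 5-bromo-2-fluorophenyl in place of 2-methoxyphenyl on a double-bonded chain carbon bound to an aromatic carbon gives a 1.1-fold lower number from compound 2 to compound 3 (0.04 log units; within the scatter), the first step that can be read at this position. The leaving arm counts a hydrogen-bond acceptor and the entering arm counts none, so in this one pair the methoxy oxygen is not required for a number of this size, and an arm carrying bromine and fluorine serves equally well within the scatter. Nothing among the available data explains why the number stays where it is.

Bromine and fluorine enter together while the methoxy group leaves, so this single pair cannot separate what each halogen does alone, and a phenyl arm carrying only the fluorine or only the bromine would be needed to tell them apart. Going by these compounds, it also remains open whether the position accepts groups of a quite different kind, such as an amine or a carboxylic acid on the phenyl arm, and whether the second 2-methoxyphenyl arm would respond to the same exchange.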